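Swapping Methoxyphenyl for Pyridyl on the Shared Core

The source may hold more compounds than are shown below. What is called first, only, known or untested is meant among the compounds shown, and "the series" means these compounds.

Compound 3 `COc1ccc(-c2noc3cc(-c4ccccc4)n(C)c(=O)c23)cc1` gives the lowest number seen in a functional assay on CHO cells for antagonist activity at metabotropic glutamate receptor 7 (Rattus norvegicus), read by FLIPR and calcium flux (a higher number here means a weaker inhibitor, a lower number a stronger inhibitor), at 29 nM. Compound 1 `CCn1c(-c2ccccc2)cc2onc(-c3ccccc3)c2c1=O` gives 910 nM in this assay. Compound 2 `CC(C)n1c(-c2ccccc2)cc2onc(-c3ccccc3)c2c1=O` sits at the limit of > 10000 nM in this assay, at which 1 of the 3 values shown sits, reported as > 10000 nM, which is a limit rather than a number. Among the compounds with values here, the only measured step, an at least 10-fold higher number from compound 1 to compound 2 (1.04 log units; beyond the scatter), concerns the group on the ring nitrogen and not the aryl group. Compound 4 `Cn1c(-c2ccccc2)cc2onc(-c3cccnc3)c2c1=O` differs from compound 3 in that (pyridin-3-yl in place of 4-methoxyphenyl on an aromatic carbon). Within the data shown here, no measured step bears on this change, so the expectation rests on the change itself. A modest weakening is expected, a 5.2-fold higher number from compound 3 to compound 4 (0.71 log units; beyond the scatter). Compound 4 is estimated at 150 nM in this assay, with an expected range from 30 nM to 800 nM.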

Compound 4, half-maximal inhibitory concentration: 240 nM
Beside the measured number, compound 4's estimate is 1.6-fold (0.20 log units) below it; measured number inside the range.
By their numbers in this assay, from the lowest: compound 3; then compound 4; then compound 1. At a limit, above all of these: compound 2.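

The aromatic carbon of the five-membered aromatic ring turns out to matter too, not only the group on the ring nitrogen: in this assay, pyridin-3-yl in place of 4-methoxyphenyl gives an 8.3-fold higher number from compound 3 to compound 4 (0.92 log units; beyond the scatter). This single swap changes both the ring atoms and the presence of the methoxy group, and the step cannot tell these two apart. Within the data shown here, nothing measured so far accounts for the size of this step.

Open, from the compounds shown here alone, is what a 4-fluorophenyl or a pyridin-4-yl group would give at this place. Also open, going by these compounds, is how a plain phenyl there would compare with a methyl on the ring nitrogen.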